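Legumain inhibitors: acyl variation on the proline nitrogen

This account rests on a few compounds, and the source may have more. Where it says the series, first, only, none or still open, it means among the compounds named here.

Measured compounds:
compound 1 `CCOC(=O)/C=C/C(=O)N(CC(N)=O)NC(=O)[C@@H]1CCCN1C(=O)[C@H]1CCCCN1C(C)=O` gives 638 nM in an assay on isolated protein for inhibition of legumain (Mus musculus), read by fluorescence, with stated times of 30 s and 2.5 h; on this read-out higher numbers stand for weaker inhibition and lower numbers for stronger inhibition;
compound 2 `CCOC(=O)/C=C/C(=O)N(CC(N)=O)NC(=O)[C@@H]1CCCN1C(C)=O` gives 8.3 nM in this assay;
compound 3 `CCOC(=O)/C=C/C(=O)N(CC(N)=O)NC(=O)[C@@H]1CCCN1C(=O)C1(NC(C)=O)CC1` gives 9.3 nM in this assay.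

Compound 3 stands second of the three numbers, with compound 2 within the scatter of it and compound 1 far weaker (a 69-fold lower number from compound 1 to compound 3 (1.84 log units; beyond the scatter)). Compound 4 `CCOC(=O)/C=C/C(=O)N(CC(N)=O)NC(=O)[C@@H]1CCCN1C(=O)C(NC(C)=O)=C(C)C` changes this position: a group of 8 heavy atoms (6 carbon, 1 nitrogen, 1 oxygen; no ring) in place of a group of 7 heavy atoms (5 carbon, 1 nitrogen, 1 oxygen; one three-membered non-aromatic ring of carbon only), on a carbonyl carbon. Among the compounds with values here, the nearest precedent is a 1.1-fold higher number from compound 2 to compound 3 (0.05 log units; within the scatter), showing that swapping methyl for 1-acetamidocyclopropyl at this carbonyl carbon left the number within the scatter, while only the larger group of compound 1 cost much (a 77-fold lower number from compound 1 to compound 2 (1.89 log units; beyond the scatter)). A small acyclic group of similar size is therefore expected to give a step of about a 1.3-fold higher number from compound 3 to compound 4 (0.11 log units; within the scatter), no clear direction beyond the scatter. Compound 4 is estimated at 12 nM, range 4 nM to 40 nM.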

Compound 4, half-maximal inhibitory concentration: 148 nM
Compound 4: middle estimate off by 12-fold (1.09 log units), on the low side; the whole stated range lies below it.
By their numbers in this assay, from the lowest: compounds 2 and 3 (each within the scatter of the next); then compound 4; then compound 1.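

Replacing 1-acetamidocyclopropyl with the acyclic group gives a 16-fold higher number from compound 3 to compound 4 (1.20 log units; beyond the scatter) with donor and acceptor counts unchanged, so this position separates groups of similar heavy-atom count and not only large groups from small ones. The same acyclic group set against methyl gives an 18-fold higher number from compound 2 to compound 4 (1.25 log units; beyond the scatter) and set against the group with the six-membered ring gives a 4.3-fold lower number from compound 1 to compound 4 (0.63 log units; beyond the scatter) so the listed groups spread widely at this carbonyl carbon. Going by these compounds, whether a cyclobutane ring in place of the cyclopropane ring, or a free amine in place of the acetamide, keeps the number of the cyclopropyl compound stays open. No measurement at hand offers an explanation for these steps.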